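Working notes: from compound 3 to compound 4

This account rests on a few compounds, and the source may have more. Where it says the series, first, only, none or still open, it means among the compounds named here.

Compound 1 `C[C@@H](c1ccc(NC(=O)N2CC(c3ccc(N)nc3)C2)cc1)N1Cc2ccccc2C1=O` gives 220000 nM in a physicochemical assay for solubility, read by LC-MS, in phosphate buffer, with a stated time of 24 h, at pH 6.8; on this read-out higher numbers stand for higher solubility and lower numbers for lower solubility
Compound 2 `C[C@H](NC(=O)c1ncccn1)c1ccc(NC(=O)N2CC(c3ccc(N)nc3)C2)cc1` gives 300000 nM
Compound 3 `C[C@@H](c1ccc(NC(=O)N2CC(c3cncc(N)c3)C2)cc1)N1Cc2ccccc2C1=O` gives 35000 nM

Compound 3 holds the lowest of the three numbers, and its gaps to compound 1 and compound 2 both lie beyond the scatter. Compound 4 `C[C@H](NC(=O)c1ncccn1)c1ccc(NC(=O)N2CC(c3cncc(N)c3)C2)cc1` differs from compound 3 at one place (a group of 9 heavy atoms (5 carbon, 3 nitrogen, 1 oxygen; one six-membered aromatic ring with 2 hetero atoms) in place of a group of 10 heavy atoms (8 carbon, 1 nitrogen, 1 oxygen; one five-membered non-aromatic ring with 1 hetero atom, one six-membered aromatic ring of carbon only), on a saturated chain carbon bound to an aromatic carbon and a saturated chain carbon). The same exchange has been measured once (a 1.4-fold higher number from compound 1 to compound 2 (0.13 log units; within the scatter)), and that step stays within the scatter. The larger step (a 6.3-fold lower number from compound 1 to compound 3 (0.80 log units; beyond the scatter)) lies at a different place, and compound 4 keeps that change. On this single precedent, no step beyond the scatter is expected in this assay. The estimated step is small (a 1.4-fold higher number from compound 3 to compound 4 (0.14 log units; within the scatter)). For compound 4 the expected value is 48000 nM in an estimated range from 20000 nM to 120000 nM for now.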

Compound 4, solubility: 300000 nM
Compound 4: middle estimate off by 6.3-fold (0.80 log units), on the low side; the measured number lies above the stated range.
By their numbers in this assay, from the lowest: compound 3; then compounds 1, 2 and 4 (each within the scatter of the next).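

In this assay, ((pyrimidin-2-yl)carbonyl)amino on the saturated chain carbon gives an 8.6-fold higher number from compound 3 to compound 4 (0.93 log units; beyond the scatter) with 5-aminopyridin-3-yl on the saturated ring carbon, whereas the same exchange gives a 1.4-fold higher number from compound 1 to compound 2 (0.13 log units; within the scatter) with 6-aminopyridin-3-yl. The aminopyridinyl exchange likewise gives a 6.3-fold lower number from compound 1 to compound 3 (0.80 log units; beyond the scatter) with the group of 10 heavy atoms but no change at the digits printed from compound 2 to compound 4 (within the scatter) with ((pyrimidin-2-yl)carbonyl)amino, so in these four compounds the two changes do not add. No measured evidence accounts for this interaction.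

From the compounds shown here alone, whether it persists with a morpholine amide on the saturated chain carbon remains open, as does its behaviour with a dimethylamino group on the pyridine.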